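Methylsulfanyl in Place of Ethyl: What to Expect

The compounds below may be only part of what the source reports. "The series", "measured", "known", "first", "only" and "open" are said of these compounds alone.

Three measured compounds share one core and differ only in the group on the amide-type nitrogen. Compound 1 `NCCNC(=O)c1cc2ccccc2oc1=O` carries a 2-aminoethyl group there, and in an in vitro assay on BTI-TN-5B1-4 cells for inhibition of Amine oxidase [flavin-containing] B (Homo sapiens), read by fluorescence (on this read-out lower numbers stand for stronger inhibition and higher numbers for weaker inhibition), compound 1 gives 7680 nM. For the measured compounds named here, compound 2 `Cc1cccc(NC(=O)c2cc3ccccc3oc2=O)c1` carries a 3-methylphenyl group instead, and in this assay compound 2 gives 600 nM; the step of a 13-fold lower number from compound 1 to compound 2 (1.11 log units; beyond the scatter) is the only single-change step among the measured compounds. Compound 3 `CCc1ccc(NC(=O)c2cc3ccccc3oc2=O)cc1` carries a six-membered aromatic ring of carbon only bearing an ethyl group, and in this assay compound 3 gives 890 nM. Compound 3 thus stands second highest of the three numbers, though its gap to compound 2 lies within the scatter, while its gap to compound 1 is beyond it.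

Compound 4 `CSc1ccc(NC(=O)c2cc3ccccc3oc2=O)cc1` is not yet measured. It differs from compound 3 by methylsulfanyl in place of ethyl on an aromatic carbon, on an aromatic carbon para to a large group. Going by the values given here, none of the measured steps changes a group on that ring; the single known step concerns the amide-type nitrogen, so there is no direct guide. The step of a 1.2-fold lower number from compound 3 to compound 4 (0.07 log units; within the scatter) is therefore expected to lie within the scatter, in no clear direction. Compound 4 is estimated at 750 nM, with a range from 300 nM to 2000 nM.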

Compound 4, half-maximal inhibitory concentration: 2840 nM
For compound 4 the middle estimate is 3.8-fold (0.58 log units) below the measured one; measured number above the stated range.
By their numbers in this assay, from the lowest: compounds 2 and 3 (each within the scatter of the next); then compound 4; then compound 1.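

In this assay, for the compounds shown here, the change on the ring gives a 3.2-fold higher number from compound 3 to compound 4 (0.50 log units; beyond the scatter), so inhibition weakens: the group on this aromatic carbon, para to a large group, matters, and the earlier compounds could not show this because none of their steps touched the ring. The change is also a small one by count, since ethyl and methylsulfanyl each hold 2 heavy atoms, and the swap replaces one carbon with one sulfur and adds one hydrogen-bond acceptor, yet even this exchange moves the number beyond the scatter. No measurement available here explains why the number rises, so the step stands as an observation without a known cause.

On these data alone, it remains open whether the weaker inhibition is tied to sulfur itself or would also appear with other groups at this place, such as a methoxy group, a chlorine atom or a longer chain like propyl. As far as these compounds go, it is also open whether the same swap would have a step of similar size on a ring carrying its group elsewhere, or with a different group on the amide-type nitrogen.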